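A few compounds are considered here, and "the series" means these few. Any claim that something is new, unique, unknown or untested is made for them only; others in the source may bear on it.

Of the compounds shown here, three have so far been measured in a functional assay on KB 3-1 cells (Homo sapiens) for cytotoxicity, read by MTT assay, with a stated time of 68 h; on this read-out lower numbers stand for stronger inhibition and higher numbers for weaker inhibition. Compound 1 `O=C(Nc1cccc(-c2ccccc2C(F)(F)F)c1)C(Cl)Cl` gives 35900 nM, and compound 3 `CC(C)Oc1ccc(-c2cc(NC(=O)C(Cl)Cl)cc(-c3ccc(OC(C)C)cc3)c2)cc1` gives 8850 nM. For compound 2 `O=C(Nc1cccc(-c2ccsc2)c1)C(Cl)Cl` the assay reports only a limit, > 50000 nM. Compound 2 thus sits at the limit of > 50000 nM in this assay, at which 1 of the 3 values shown sits, and no number is known for it. Compound 4 `O=C(Nc1cccc(-c2cccs2)c1)C(Cl)Cl` has not yet been measured; it differs from compound 2 by thiophen-2-yl in place of thiophen-3-yl on an aromatic carbon. Among the compounds with values here, no step between two measured compounds is available to calibrate a change of this kind. The step of a number no higher from compound 2 to compound 4 (the limit leaves the size open) is expected to be small, with no direction beyond the usual scatter. Compound 4 is therefore expected to reach only the limit as well, and its estimate is 50000 nM, with a range from 25000 nM to 100000 nM.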

Compound 4, half-maximal inhibitory concentration: > 50000 nM
Compound 4 ended at the assay's limit (the forecaster's own chance of this, stated with the estimate: 65%); the middle value lies on the limit itself.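

Compound 2 and compound 4 both stop at the assay's limit, so no step between them can be read: the limit of > 50000 nM in this assay, at which 2 of the 4 values shown sit.

The compounds shown leave open how thiophen-2-yl and thiophen-3-yl truly compare on the shared core.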